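Adding fluoromethyl to compound 2

The source may hold more compounds than are shown below. What is called first, only, known or untested is meant among the compounds shown, and "the series" means these compounds.

Compound 1 `CCC(=O)N1C[C@@H]2[C@H](C1)[C@H]2NC(=O)c1cc(C(=O)NC)c2c(c1)[C@H](c1ccccc1)CO2` gives >= 163 ug/mL (a limit)
Compound 2 `CNC(=O)c1cc(C(N)=O)cc2c1OC[C@H]2c1ccccc1` gives >= 144 ug/mL (a limit)

In a physicochemical assay for solubility (on this read-out higher numbers stand for higher solubility and lower numbers for lower solubility), compound 2 stands at >= 144 ug/mL as a limit and not a number. For the measured compounds named here, the one measured step that the two limits leave unreadable from compound 1 to compound 2 falls on an amide-type nitrogen and gives no readable size. Compound 3 `CNC(=O)c1cc(C(N)=O)cc2c1O[C@H](CF)[C@H]2c1ccccc1` differs from compound 2 by fluoromethyl in place of hydrogen on a saturated ring carbon with fluoromethyl in place of hydrogen on a saturated ring carbon. Going by the values given here, no measured step gives a size for this change, so no shift beyond the scatter is expected in this assay in either direction. The expected step is a step that the limit leaves unreadable from compound 2 to compound 3 on this estimate. For compound 3 the estimated value is 150 ug/mL with an expected range from 70 ug/mL to 220 ug/mL (estimate).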

Compound 3, solubility: >= 128 ug/mL
Compound 3 was reported as a limit; the forecaster's own chance of this, stated with the estimate: 55%; the middle value lies beyond the limit too.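

Compound 2 and compound 3 both stand as limits in this assay, and the step between them cannot be read. The compounds shown leave open what size, if any, fluoromethyl in place of hydrogen on a saturated ring carbon has in this assay.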